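Methoxy on the anilino ring of a thiazole acetamide series

The source may hold more compounds than are shown below. What is called first, only, known or untested is meant among the compounds shown, and "the series" means these compounds.

Compound 1 `Cc1nc(SCC(=O)Nc2nc(-c3ccc(Cl)cc3)cs2)n(Nc2ccccc2)c1C` is the reference point of the series. Going by the values given here, in a functional assay on MDA-MB-468 cells (Homo sapiens) for antiproliferative activity, read by sulforhodamine B assay, with a stated time of 48 h (on this read-out higher numbers stand for lower toxicity in this test and lower numbers for higher toxicity in this test), compound 1 gives 40400 nM, the only plain number in hand for this set. Among the compounds with values here, compound 2 `Cc1ccc(Nn2c(SCC(=O)Nc3nc(-c4ccccc4)cs3)nc(C)c2C)cc1` is a close relative but differs from compound 1 in more than one place, so no single step can be drawn between them. In this assay compound 2 reaches only a limit of the assay, > 100000 nM; the limit of > 100000 nM in this assay, at which 1 of the 2 values shown sits, sums up where that limit sits. The two values together show that the series as a whole is weak in this assay, with compound 1 on the measurable side and compound 2 beyond reach.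

Compound 3 `COc1ccc(Nn2c(SCC(=O)Nc3nc(-c4ccc(Cl)cc4)cs3)nc(C)c2C)cc1` is not yet measured. Relative to compound 1 the change is methoxy in place of hydrogen on an aromatic carbon, in words: methoxy in place of hydrogen on an aromatic carbon. Within the data shown here, no step between measured compounds informs this change directly. The expectation is a step from compound 1 to compound 3 of a 1.5-fold higher number from compound 1 to compound 3 (0.17 log units; within the scatter), that is, little or no movement beyond the scatter, with some chance of drifting toward a limit. Compound 3 is therefore estimated at 60000 nM, within a range from 20000 nM to 150000 nM.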

Compound 3, concentration lethal to 50% of the cells: > 100000 nM
Compound 3 ended at the assay's limit; the forecaster's own chance of this, stated with the estimate: 40%; middle value at least 1.6-fold (0.22 log units) from the limit.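

Going by these compounds alone, on an aromatic carbon para to a large group, phenyl to 4-methoxyphenyl gives an at least 2.4-fold higher number from compound 1 to compound 3 (0.39 log units; beyond the scatter) in this assay, the first comparison in the set that isolates one place, and it shows that this position of the anilino ring is not indifferent to substitution: methoxy moves the read-out toward lower toxicity in this test. For compound 3 the entry > 100000 nM is a limit of the assay and not a number, so the step fixes a minimum size for the change and no full size. Compound 1 therefore remains the only compound in the set with a plain value, and the rest of the series now gathers at one ceiling: the limit of > 100000 nM in this assay, at which 2 of the 3 values shown sit.

Only methoxy is shown at this carbon, and whether a fluorine, a hydroxyl or an amine in its place would push the read-out the same way, or leave it close to compound 1, stays open. On these data alone, how far compound 3 lies past the limit also stays open, as does whether the same change would act alike on a different aryl group elsewhere on the shared core.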